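Aryl Variation on the Shared Core: Compound 3

This account rests on a few compounds, and the source may have more. Where it says the series, first, only, none or still open, it means among the compounds named here.

Compound 1 `O=C(NO)c1ccc(NCc2nc(-c3ccc(Br)o3)nn2-c2ccccc2)cc1` and compound 2 `Cc1ccccc1-c1nc(CNc2ccc(C(=O)NO)cc2)n(-c2ccccc2)n1` share one core and differ only in the aryl group on an aromatic carbon. In an assay on Sf9 cells for inhibition of protein deacetylase HDAC6 (Homo sapiens), read by fluorescence, with a stated time of 40 min, tested at 100 nM (on this read-out lower numbers stand for less inhibition and higher numbers for more inhibition at the one concentration tested (going by the name of the read-out)), compound 1 gives 55.8%, and compound 2 gives 53.2%. The step between them, a number 2.6 percentage points lower from compound 1 to compound 2 (within the scatter), is within the scatter. On the numbers shown compound 2 stands lowest of the two, but because the step of a number 2.6 percentage points lower from compound 1 to compound 2 (within the scatter) is within the scatter no order between the two can be read.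

Compound 3 `O=C(NO)c1ccc(NCc2nc(-c3ccc(C(F)(F)F)cc3)nn2-c2ccccc2)cc1` is not yet measured. It differs from compound 2 in one place: 4-(trifluoromethyl)phenyl in place of 2-methylphenyl on an aromatic carbon. For the measured compounds named here, the only measured step that bears on this change is the aryl exchange from compound 1 to compound 2, which stayed within the scatter. Two different aryl groups at this position gave read-outs within the scatter of each other, so for this assay the expectation for compound 3 is a step of a number 1.8 percentage points higher from compound 2 to compound 3 (within the scatter) that does not go beyond the scatter in either direction. Compound 3 is therefore estimated at 55%, with a range of 35% to 72%.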

Compound 3, a percentage reported as inhibition, at one concentration (the size of the read-out at that concentration, not a potency): 41.6%
The estimate for compound 3 lay 13.4 percentage points above the measured number; low and high end bracket the measured number.
By their numbers in this assay, from the lowest: compound 3; then compounds 2 and 1 (each within the scatter of the next).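

In this assay, the aromatic carbon between two ring nitrogen atoms turns out not to accept every aryl group alike: a number 11.6 percentage points lower from compound 2 to compound 3 (beyond the scatter) and a number 14.2 percentage points lower from compound 1 to compound 3 (beyond the scatter) both go beyond the scatter, whereas a number 2.6 percentage points lower from compound 1 to compound 2 (within the scatter) did not. Among the three aryl groups, 4-(trifluoromethyl)phenyl is the only one that separates from the others, leaving compound 3 lowest of the set, though both steps are modest and compound 1 and compound 2 still cannot be ordered. No measurement shown here offers an explanation for the lower number with this group, and the step stands as an observation only.

Open, on these data alone, is whether the lower number goes with the trifluoromethyl group itself or with its place on the phenyl ring, a question on which 4-methylphenyl and 2-(trifluoromethyl)phenyl at this carbon would bear. Also open is how a phenyl ring carrying an amine or a carboxylic acid would read here, and whether the order of these compounds holds beyond the single concentration tested.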